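Will the Methoxy Gain Carry Over to Compound 4?

The source may hold more compounds than are shown below. What is called first, only, known or untested is meant among the compounds shown, and "the series" means these compounds.

Compound 1 `c1ccc(CN2CCC3(CC2)OCCc2c3csc2-c2ccccc2)cc1` is the starting point. In an assay on membranes from brain for displacement of a labelled ligand from Sigma non-opioid intracellular receptor 1 (Cavia porcellus), read by scintillation counting, with a stated time of 120 min (a lower number here means a stronger inhibitor, a higher number a weaker inhibitor), compound 1 gives 4.5 nM. Compound 2 `COc1ccc(-c2scc3c2CCOC32CCN(Cc3ccccc3)CC2)cc1` differs from it in one place, (methoxy in place of hydrogen on an aromatic carbon), and in this assay compound 2 gives 1.5 nM; the change made a 3.0-fold lower number from compound 1 to compound 2 (0.48 log units; beyond the scatter). Compound 3 `COC1Cc2c(-c3ccccc3)csc2C2(CCN(Cc3ccccc3)CC2)O1` is built on a related but different core; the difference between the two cores is not broken down here. In this assay compound 3 gives 5.4 nM, a number that sits within the usual scatter of compound 1. Compound 4 `COc1ccc(-c2csc3c2CC(OC)OC32CCN(Cc3ccccc3)CC2)cc1` carries the same change on the core of compound 3, (methoxy in place of hydrogen on an aromatic carbon), and the place is described in the same words as before, so this counts as the same change. Since the earlier occurrence gave a 3.0-fold lower number from compound 1 to compound 2 (0.48 log units; beyond the scatter), a step of similar size is expected for compound 4, a 2.7-fold lower number from compound 3 to compound 4 (0.43 log units; beyond the scatter). Compound 4 is therefore estimated at 2 nM, with a likely range from 0.8 nM to 5 nM. This rests on a single precedent and on compound 3 starting at 5.4 nM, so it remains an expectation until the measurement arrives.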

Compound 4, inhibition constant: 7.1 nM
The estimate for compound 4 lay 3.6-fold (0.55 log units) below the measured number; the whole stated range lies below it.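

On the core of compound 3, replacing phenyl with 4-methoxyphenyl in this assay gives a 1.3-fold higher number from compound 3 to compound 4 (0.12 log units; within the scatter), so the gain seen on the core of compound 1 does not reappear here. Set side by side, the two results for this one change do not agree, and the gap between them is larger than repeat measurements would explain: the same change on two cores in this assay, a 3.0-fold lower number (0.48 log units; beyond the scatter) from compound 1 to compound 2 and a 1.3-fold higher number (0.12 log units; within the scatter) from compound 3 to compound 4, 3.9-fold (0.60 log units) apart, beyond the scatter of two such steps. Going by these compounds alone, this shows that a gain from methoxy on one core cannot simply be assumed on the other, but with only one pair per core it does not show why the results part, nor how the change would behave on any further core.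

The compounds shown leave open whether another group at this place on the phenyl ring, such as a hydroxyl or a chlorine atom, would also give different results on the two cores. They also leave open which part of the difference between the two cores goes with the different outcomes, since that difference is not broken down into single changes.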